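Swapping the phenylcyclobutyl arm for a pyridinyl cyclopropyl

The source may hold more compounds than are shown below. What is called first, only, known or untested is meant among the compounds shown, and "the series" means these compounds.

Compound 1 `Cc1cnc(NCC2(c3ccccc3)CCC2)c(=O)n1CC(=O)NCc1ccc2c(N)noc2c1` is the starting point. In a physicochemical assay for acid dissociation, compound 1 gives 8.6, the highest of the three numbers measured. Compound 3 `Cc1cnc(NCC2(c3ccccc3)CCC2)c(=O)n1CC(=O)NCc1ccc2[nH]nc(O)c2c1` gives 6.3, and compound 2 `COc1cccc(S(=O)(=O)Nc2cccn(CC(=O)NCc3ccc4[nH]nc(N)c4c3)c2=O)c1` gives 3.6. The only single-point step among these, a number 2.30 log units lower from compound 1 to compound 3 (beyond the scatter), concerns a change at the amide end of the molecule, far from where compound 4 differs. Compound 4 `Cc1cnc(NCC2(c3ccccn3)CC2)c(=O)n1CC(=O)NCc1ccc2c(N)noc2c1` carries 1-(pyridin-2-yl)cyclopropyl in place of 1-phenylcyclobutyl on a saturated chain carbon bound to a nitrogen on an aromatic ring. Among the measured compounds shown here, no measured step touches that part of the structure, so nothing here points to a shift beyond the scatter, and compound 4 is expected to sit close to compound 1, at a number 0.10 log units lower from compound 1 to compound 4 (within the scatter). The estimate for compound 4 is therefore 8.5, with a range from 7.9 to 9.1.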

Compound 4, acid dissociation constant: 8.6
Estimate against measurement, compound 4: 0.10 log units below; the measured number falls inside the stated range.
By their numbers in this assay, from the lowest: compound 2; then compound 3; then compounds 1 and 4 (each within the scatter of the next).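

In this assay, among the compounds shown here, putting 1-(pyridin-2-yl)cyclopropyl in place of 1-phenylcyclobutyl gives no change at the digits printed from compound 1 to compound 4 (within the scatter), the only measured step at this place on a saturated chain carbon bound to a nitrogen on an aromatic ring. This arm therefore takes a three-membered carbon ring and a pyridine ring together with no shift beyond the scatter. No measurement here offers an explanation for this result.

Both rings differ at once, so the compounds shown cannot separate their contributions, as 1-phenylcyclopropyl would. On these data alone, how an arm carrying an amine or a carboxylic acid would read also stays open.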